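A few compounds are considered here, and "the series" means these few. Any claim that something is new, unique, unknown or untested is made for them only; others in the source may bear on it.

Measured compounds:
compound 1 `O=C1/C(=C/c2ccccc2)CCC/C1=C\c1cccc([N+](=O)[O-])c1`, 9440 nM
compound 2 `Cc1ccc(/C=C2\CCC/C(=C\c3ccccc3[N+](=O)[O-])C2=O)cc1`, 7770 nM
compound 3 `O=C1/C(=C/c2ccc(Cl)cc2)CCC/C1=C\c1ccccc1[N+](=O)[O-]`, 9380 nM

Compound 1 holds the highest of the three numbers in a functional assay on L1210 cells (Mus musculus) for cytotoxicity, with a stated time of 48 h (on this read-out lower numbers stand for stronger inhibition and higher numbers for weaker inhibition), but its gaps to compound 3 and to compound 2 both lie within the scatter, so no order among the three is claimed. Among the measured compounds shown here, the only measured step, a 1.2-fold higher number from compound 2 to compound 3 (0.08 log units; within the scatter), also lies within the scatter.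

Compound 4 `CN(C)c1ccc(/C=C2\CCC/C(=C\c3cccc([N+](=O)[O-])c3)C2=O)cc1` differs from compound 1 by dimethylamino in place of hydrogen on an aromatic carbon. For the measured compounds named here, no measured step touches that change; the one known step concerns a different substituent on the same ring and was itself flat. The expected step of a 1.0-fold lower number from compound 1 to compound 4 (0.02 log units; within the scatter) is therefore none beyond the scatter. For compound 4 the estimate is 9000 nM, with a range of 3000 nM to 27000 nM.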

Compound 4, half-maximal inhibitory concentration: 156000 nM
Compound 4: the middle estimate sits 17-fold (1.24 log units) below what was measured; the measured number lies above the stated range.
By their numbers in this assay, from the lowest: compounds 2, 3 and 1 (each within the scatter of the next); then compound 4.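

In this assay, among the compounds shown here, the change from phenyl to 4-(dimethylamino)phenyl gives a 17-fold higher number from compound 1 to compound 4 (1.22 log units; beyond the scatter) and is the first step to pass the scatter. The earlier step, a 1.2-fold higher number from compound 2 to compound 3 (0.08 log units; within the scatter), showed no such movement, so this aromatic carbon, para to a large group, is not indifferent to every substituent. Nothing available explains the size of this step.

From the compounds shown here alone, whether a diethylamino or methoxy group on this carbon would give a similar step remains open. So does whether dimethylamino would act alike on the core of compound 2.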